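The source may hold more compounds than are shown below. What is called first, only, known or untested is meant among the compounds shown, and "the series" means these compounds.

Compound 1 `CNC(=O)[C@@H](c1ccccc1)N1CCn2c(CC3CC3)nc(Cl)c2[C@@H]1CCc1ccc(C(F)(F)F)cc1`: 35 nM in a functional assay on CHO cells for antagonist activity at Orexin receptor type 2 (Homo sapiens), read by FLIPR and calcium flux; a lower number here means a stronger inhibitor, a higher number a weaker inhibitor.
Compound 2 `CCc1nc(C(F)(F)F)c2n1CCN([C@@H](C(=O)NC)c1ccccc1)[C@H]2CCc1ccc(C(F)(F)F)cc1`: 11 nM in this assay.

Compound 1 holds the higher of the two numbers; compound 2 sits lower by a margin beyond the scatter. Compound 3 `CNC(=O)[C@@H](c1ccccc1)N1CCn2c(COC)nc(Cl)c2[C@@H]1CCc1ccc(C(F)(F)F)cc1` derives from compound 1 by a single change, (methoxy in place of cyclopropyl on a saturated chain carbon bound to an aromatic carbon). Among the compounds with values here, no measured pair shows this exchange, so the step in this assay is expected to be a 1.4-fold higher number from compound 1 to compound 3 (0.15 log units; within the scatter), small and toward a weaker inhibitor, possibly within the scatter. Compound 3 is estimated at 50 nM, with a range of 15 nM to 160 nM.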

Compound 3, half-maximal inhibitory concentration: 25 nM
Estimate against measurement, compound 3: 2.0-fold (0.30 log units) above; the measured number falls inside the stated range.
By their numbers in this assay, from the lowest: compound 2; then compounds 3 and 1 (each within the scatter of the next).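

On the saturated chain carbon bound to an aromatic carbon, methoxy in place of cyclopropyl gives a 1.4-fold lower number from compound 1 to compound 3 (0.15 log units; within the scatter) in this assay and the two compounds stand level. At this place, then, the cyclopropylmethyl ring can give way to open-chain methoxymethyl, with one hydrogen-bond acceptor, without a change beyond the scatter. No evidence at hand accounts for this result.

From the compounds shown here alone, whether an amine or a longer ether chain at this place would also stand level remains open. Compound 2 differs from compound 1 in more than one place, so its lower number cannot be assigned to any single group.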